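Trimming the Amide Side Chain to a Methoxy Group

The source may hold more compounds than are shown below. What is called first, only, known or untested is meant among the compounds shown, and "the series" means these compounds.

Compound 1 `C[S+]([O-])/C=C/C(=O)NC1CCCN1C(=O)/C=C/c1ccccc1` and compound 2 `CC(C)CC(=O)NC1CCCN1C(=O)/C=C/c1ccccc1` share one core and differ in a single group on a carbonyl carbon. In an ADME assay on HUVEC cells (Homo sapiens) for cytotoxicity (on this read-out higher numbers stand for an effect only at larger amounts of compound and lower numbers for an effect already at smaller amounts), compound 1 gives only a limit, > 5 ug/mL. In this assay compound 2 likewise gives only a limit, > 5 ug/mL. The step that the two limits leave unreadable from compound 1 to compound 2 therefore cannot be sized, since both values sit at the limit of > 5 ug/mL in this assay, at which 2 of the 2 values shown sit. Compound 3 `COC1CCCN1C(=O)/C=C/c1ccccc1` differs from compound 2 by methoxy in place of (isobutylcarbonyl)amino on a saturated ring carbon. No measured step covers this kind of change, so no direction in this assay can be read from the numbers shown. Compound 3 is expected to give 8 ug/mL, between 4 ug/mL and 20 ug/mL. The step is estimated as a step that the limit leaves unreadable from compound 2 to compound 3.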

Compound 3, concentration for half-maximal effect: > 5 ug/mL
Compound 3: only a limit was reported; the forecaster's own chance of this, stated with the estimate: 80%; the middle value lies beyond the limit too.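

Compound 2 and compound 3 both give only a limit, so no new step can be read between them: the limit of > 5 ug/mL in this assay, at which 3 of the 3 values shown sit. As far as these compounds go, whether methoxy in place of (isobutylcarbonyl)amino changes anything in this assay stays open.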